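Compound 2 to compound 3: a smaller side chain

The compounds below may be only part of what the source reports. "The series", "measured", "known", "first", "only" and "open" are said of these compounds alone.

Compound 1 `COc1cccc(C#Cc2cc(Cl)cn3c([N+](=O)[O-])c(CS(=O)(=O)c4ccccc4)nc23)c1` gives > 3900 nM (a limit)
Compound 2 `CC(O)(C#Cc1cc(Cl)cn2c([N+](=O)[O-])c(CS(=O)(=O)c3ccccc3)nc12)c1ccccc1` gives 18800 nM

For the measured compounds named here, in an ADME assay on HepG2 cells (Homo sapiens) for cytotoxicity, read by MTT assay, with a stated time of 72 h (a lower number here means that less compound is tolerated, a higher number that more compound is tolerated), compound 2 gives 18800 nM, the only true number so far. The value of compound 1 is only a limit: the limit of > 3900 nM in this assay, at which 1 of the 2 values shown sits. Going by the values given here, the single measured step is a step that the limit leaves unreadable from compound 1 to compound 2, so it offers no size to build on.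

Compound 3 `O=[N+]([O-])c1c(CS(=O)(=O)c2ccccc2)nc2c(C#CCCO)cc(Cl)cn12` differs from compound 2 in its side chain: 2-hydroxyethyl in place of 1-hydroxy-1-phenylethyl on a triple-bonded carbon. With no readable step as a guide, no shift beyond the usual scatter is expected, in either direction. The expected step is a 1.1-fold higher number from compound 2 to compound 3 (0.03 log units; within the scatter). Compound 3 is estimated at 20000 nM, with an expected range from 7000 nM to 60000 nM.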

Compound 3, half-maximal cytotoxic concentration: > 125000 nM
Compound 3 gave a limit, no number; the forecaster's own chance of this, stated with the estimate: 30%; middle value at least 6.2-fold (0.79 log units) away from the limit.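

This gives the first readable size for a change on this triple-bonded carbon: in this assay, 2-hydroxyethyl in place of 1-hydroxy-1-phenylethyl gives an at least 6.6-fold higher number from compound 2 to compound 3 (0.82 log units; beyond the scatter), so more compound is tolerated. Compound 3 has no true number, only a limit: the limit of > 125000 nM in this assay, at which 1 of the 3 values shown sits. The steps from compound 1 cannot be read, so 3-methoxyphenyl stays unranked against both side chains.

This change removes the aromatic ring and alters the chain at once, and the compounds shown do not separate the two. On these data alone, how an amine or a longer chain ending in hydroxy would compare remains open.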